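The source may hold more compounds than are shown below. What is called first, only, known or untested is meant among the compounds shown, and "the series" means these compounds.

Among the measured compounds shown here, compound 2, with the structure `CNC(=O)c1cc(C(=O)Nc2cnn(C)c2)cc2c1OC[C@H]2c1ccccc1`, is one of three compounds measured in a physicochemical assay for solubility (on this read-out lower numbers stand for lower solubility and higher numbers for higher solubility), and for all three only a limit is known. In this assay compound 2 gives >= 189 ug/mL, which is a limit of the assay and not a number. Compound 1, `CNC(=O)c1cc(C(=O)N[C@H]2[C@@H]3COC[C@@H]32)cc2c1OC[C@H]2c1cccc(OC)c1`, gives >= 186 ug/mL in this assay, again a limit. Compound 3, `CNC(=O)c1cc(C(=O)N[C@H]2[C@@H]3COC[C@@H]32)cc2c1OC[C@H]2C1CCOCC1`, gives >= 177 ug/mL in this assay, also a limit. The only single-point step among these, a step that the two limits leave unreadable from compound 1 to compound 3, cannot be read because the limit of >= 177 ug/mL in this assay, at which 1 of the 3 values shown sits, and the limit of >= 186 ug/mL in this assay, at which 1 of the 3 values shown sits, both stand at the ceiling of the assay; likewise the limit of >= 189 ug/mL in this assay, at which 1 of the 3 values shown sits, places compound 2 at its ceiling. Compound 4, `CCC(=O)N1C[C@@H]2[C@H](C1)[C@H]2NC(=O)c1cc(C(=O)NC)c2c(c1)[C@H](c1ccccc1)CO2`, differs from compound 2 in one place: a group of 10 heavy atoms (8 carbon, 1 nitrogen, 1 oxygen; one three-membered non-aromatic ring of carbon only, one five-membered non-aromatic ring with 1 hetero atom) in place of a group of 6 heavy atoms (4 carbon, 2 nitrogen; one five-membered aromatic ring with 2 hetero atoms), on an amide-type nitrogen. For the measured compounds named here, no measured step bears directly on this change, since every value shown is a limit. Compounds 1 and 3 carry a related saturated bicyclic amide and sit at their limits, so compound 4 is expected to remain soluble, with an estimated 150 ug/mL (range 50 ug/mL to 200 ug/mL), implying an expected step of an at least 1.2-fold lower number from compound 2 to compound 4 (0.10 log units; that floor lies within the scatter) that cannot be sized against a limit.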

Compound 4, solubility: >= 163 ug/mL
Compound 4: a limit, no number; the forecaster's own chance of this, stated with the estimate: 45%; at least 1.0-fold (0.03 log units) between middle value and limit.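

Compound 2 and compound 4 both stand only at limits in this assay, and the step between them cannot be read. The compounds shown leave open what the true solubility of each one is, and whether the exchange on the amide-type nitrogen changes it at all.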